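The source may report more compounds than this note shows. Statements on the series, on what has been measured and on what is new or still open speak of the compounds shown alone.

In a functional assay on the whole organism for positive allosteric modulation, with Mus musculus as the target (on this read-out lower numbers stand for an effect already at smaller amounts and higher numbers for an effect only at larger amounts of compound), compound 1 (`CCC(=O)N(c1ccc(Cl)c(Cl)c1)C1CCCC1O`) gives 0.4 mg/kg, the lowest of the three numbers available. Compound 2 (`CCC(=O)N(c1ccc(Cl)c(C)c1)C1CCCC1N(C)C`) is nearest at 2 mg/kg, and compound 3 (`CCC(=O)N(c1ccc(C(F)(F)F)cc1)C1CCCC1N(C)C`) is furthest at 10 mg/kg. Both gaps to compound 1 lie beyond the usual scatter. Neither compound 2 nor compound 3 carries the hydroxy group of compound 1. Among the compounds with values here, both have an amino group in its stead, and both also differ from compound 1 elsewhere, so no measured pair isolates a change at that place.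

Compound 4 (`C=CCNC1CCCC1N(C(=O)CC)c1ccc(Cl)c(Cl)c1`) keeps the rest of compound 1 and changes that one place: allylamino in place of hydroxy on a saturated ring carbon, (allylamino in place of hydroxy on a saturated ring carbon). Its step in this assay can therefore only be inferred. Within the data shown here, the closest guide is compound 2 at 2 mg/kg, with compound 3 at 10 mg/kg as a further sign that the amino-bearing compounds measured so far sit above compound 1. A step towards a higher number, beyond the scatter, is thus expected, though with wide uncertainty. The estimated change is a 5.0-fold higher number from compound 1 to compound 4 (0.70 log units; beyond the scatter). For compound 4 the expected value is 2 mg/kg, with an estimated range from 0.5 mg/kg to 8 mg/kg.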

Compound 4, dose for half-maximal effect: 0.2 mg/kg
Estimate against measurement, compound 4: 10-fold (1.00 log units) above, and the stated range ends above it.
By their numbers in this assay, from the lowest: compounds 4 and 1 (each within the scatter of the next); then compound 2; then compound 3.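

In this assay, the exchange of hydroxy for allylamino on the saturated ring carbon gives a 2.0-fold lower number from compound 1 to compound 4 (0.30 log units; within the scatter) and so leaves the read-out within the scatter. Within the data shown here, this is the only measured pair that isolates this place: allylamino brings 4 heavy atoms and a double bond where hydroxy has 1 heavy atom, while the counts of hydrogen-bond donors and acceptors stay the same, and with the rest of compound 1 held fixed the number does not move beyond the scatter. The higher numbers of compound 2 and compound 3 therefore cannot be read as the mark of an amino group at this place, as both compounds also differ from compound 1 elsewhere, and no measurement shown offers a reason for the result.

The compounds shown leave open how a saturated propylamino chain, a primary amine or a carboxylic acid would read at this place. They also leave open how the dimethylamino group of compound 2 and compound 3 would read on the core of compound 1, which would separate the effect of that group from the changes elsewhere.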